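Swapping Chloro for Iodo: What Compound 4 May Show

The source may hold more compounds than are shown below. What is called first, only, known or untested is meant among the compounds shown, and "the series" means these compounds.

This study compares four compounds in a functional assay on HeLa cells (Homo sapiens); on this read-out lower numbers stand for an effect already at smaller amounts and higher numbers for an effect only at larger amounts of compound. Compound 1 `CCOC(=O)c1cc(CCl)[nH]n1` carries a chloromethyl group on its core. In this assay compound 1 gives only a limit of > 100 ug/mL, not a number. Compound 2 `CCOC(=O)c1cc(CI)[nH]n1` differs from compound 1 by iodo in place of chloro on a saturated chain carbon bound to an aromatic carbon. In this assay compound 2 likewise reaches only a limit of > 100 ug/mL. The step that the two limits leave unreadable from compound 1 to compound 2 therefore cannot be read, because both values sit at the limit of > 100 ug/mL in this assay, at which 2 of the 3 values shown sit.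

Compound 3 `CCOC(=O)c1cc(CCl)nn1[C@@H]1O[C@H](COC(C)=O)[C@@H](OC(C)=O)[C@H]1OC(C)=O` carries the same chloromethyl group on a different core; the difference between the two cores is not broken down here. In this assay, going by the values given here, compound 3 gives 32 ug/mL, the only number among the three measured compounds. Compound 4 `CCOC(=O)c1cc(CI)nn1[C@@H]1O[C@H](COC(C)=O)[C@@H](OC(C)=O)[C@H]1OC(C)=O` has not yet been measured. It differs from compound 3 by iodo in place of chloro on a saturated chain carbon bound to an aromatic carbon, the same change as between compound 1 and compound 2, made at the same place.

Since the measured example of this change is hidden by the limits, it gives no size to carry over. The expectation for compound 4 in this assay therefore rests on compound 3 alone, with its 32 ug/mL, and on the small extent of the change. The step of no change at the digits printed from compound 3 to compound 4 (within the scatter) is expected to be small. Compound 4 is estimated at 32 ug/mL, with a range from 10 ug/mL to 100 ug/mL.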

Compound 4, concentration for half-maximal effect: 5.5 ug/mL
Estimate against measurement, compound 4: 5.8-fold (0.76 log units) above, and the stated range ends above it.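

In this assay, iodo in place of chloro on the core of compound 3 gives a 5.8-fold lower number from compound 3 to compound 4 (0.76 log units; beyond the scatter), so on this core the change has a real effect, one that repeat-measurement noise would not explain. On the core of compound 1, the same change cannot be read, because compound 1 and compound 2 each give a limit and not a number: the limit of > 100 ug/mL in this assay, at which 2 of the 4 values shown sit. The series therefore shows the change at work on one core only; it does not show that the step carries from one core to the other, since the pair on the core of compound 1 could hide a similar step, a smaller one or none, and a single readable pair sets no rule for the series.

The compounds shown leave open whether the effect follows the halogen, for instance whether bromo on the same saturated chain carbon bound to an aromatic carbon would fall nearer to chloro or to iodo. They also leave open whether a group without any halogen there, such as an amine or a hydroxyl, would keep any of the effect seen with compound 4.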